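Bromophenyl to dimethoxyphenyl: expected cytotoxicity on Vero cells

The source may report more compounds than this note shows. Statements on the series, on what has been measured and on what is new or still open speak of the compounds shown alone.

Compound 1 `Fc1ccc(Nc2ccnc(NCCCNc3ccnc4cc(Cl)ccc34)n2)cc1` in an ADME assay on Vero cells (Chlorocebus sabaeus) for cytotoxicity, read by neutral red uptake, with a stated time of 72 h; on this read-out higher numbers stand for weaker inhibition and lower numbers for stronger inhibition: 13700 nM
Compound 2 `Clc1ccc2c(NCCCCNc3nccc(Nc4ccccc4)n3)ccnc2c1` in this assay: 14300 nM
Compound 3 `Clc1ccc2c(NCCCCNc3nccc(Nc4ccc(Br)cc4)n3)ccnc2c1` in this assay: 10000 nM

Compound 3 has the lowest of the three numbers, yet its gaps to compound 1 and to compound 2 both lie within the scatter, so the three compounds cannot be ranked. For the measured compounds named here, the only single-place step measured, a 1.4-fold lower number from compound 2 to compound 3 (0.16 log units; within the scatter), is itself within the scatter.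

Compound 4 `COc1cc(Nc2ccnc(NCCCCNc3ccnc4cc(Cl)ccc34)n2)cc(OC)c1` differs from compound 3 by 3,5-dimethoxyphenyl in place of 4-bromophenyl on a nitrogen on an aromatic ring. Going by the values given here, no measured step involves a dimethoxyphenyl group; the bromo step is the only one that bears on this change, and it was small. A step no larger than the scatter is therefore expected. For compound 4 in this assay the estimated value is 12000 nM, ranging from 5000 nM to 30000 nM, which is expected to amount to a 1.2-fold higher number from compound 3 to compound 4 (0.08 log units; within the scatter).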

Compound 4, half-maximal inhibitory concentration: 12500 nM
Compound 4: the middle estimate sits 1.0-fold (0.02 log units) below what was measured, within the range that was stated.
By their numbers in this assay, from the lowest: compounds 3, 4, 1 and 2 (each within the scatter of the next).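

On a nitrogen on an aromatic ring, 3,5-dimethoxyphenyl gives no step beyond the scatter in this assay (a 1.3-fold higher number from compound 3 to compound 4 (0.10 log units; within the scatter)), and the same holds against plain phenyl (a 1.1-fold lower number from compound 2 to compound 4 (0.06 log units; within the scatter)). The group on this nitrogen can therefore gain 2 hydrogen-bond acceptors and grow from 7 to 10 heavy atoms with no readable shift in the number. No evidence is at hand to explain this result. As far as these compounds go, whether an amine or a carboxylic acid on the phenyl ring would also leave the number unchanged stays open.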